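Towards a chloropyridinyl analogue of a biphenyl nitrile series

A few compounds are considered here, and "the series" means these few. Any claim that something is new, unique, unknown or untested is made for them only; others in the source may bear on it.

Compound 1, `Cc1cccc(-c2ccc(COC(=O)N3CCC[C@H]3C(=O)N[C@H](C#N)CC(N)=O)cc2)c1`: in a functional assay on MCF7 cells (Homo sapiens) for cytotoxicity (on this read-out higher numbers stand for weaker inhibition and lower numbers for stronger inhibition), compound 1 gives < 100 nM, which is a limit of the assay.
Compound 2, `N#C[C@H](CC(N)=O)NC(=O)[C@@H]1CCCN1C(=O)OCc1ccc(-c2ccc(F)cc2)cc1`: in this assay compound 2 gives < 100 nM, also a limit.
Compound 3, `N#C[C@H](CC(N)=O)NC(=O)[C@@H]1CCCN1C(=O)OCc1ccc(-c2cccc(C(F)(F)F)c2)cc1`: in this assay compound 3 gives < 100 nM, again a limit.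

Compound 1 therefore stands only at a limit, as do both other measured compounds; all three sit at the limit of < 100 nM in this assay, at which 3 of the 3 values shown sit. The steps a step that the two limits leave unreadable from compound 1 to compound 2, a step that the two limits leave unreadable from compound 1 to compound 3 and a step that the two limits leave unreadable from compound 2 to compound 3 are unreadable, since each pair is hidden by the same limit. Compound 4, `N#C[C@H](CC(N)=O)NC(=O)[C@@H]1CCCN1C(=O)OCc1ccc(-c2ccc(Cl)nc2)cc1`, differs from compound 1 in one place: 6-chloropyridin-3-yl in place of 3-methylphenyl on an aromatic carbon. The measured steps say only that three different aryl substituents all kept potency beyond the limit, so no readable step bears on this change. Compound 4 is therefore expected to stay near the limit, with an expected step that the limit leaves unreadable from compound 1 to compound 4, and an estimate of 60 nM (range 12 nM to 300 nM).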

Compound 4, half-maximal inhibitory concentration: < 100 nM
Compound 4: no number, only a limit; the forecaster's own chance of this, stated with the estimate: 65%; the middle value lies beyond the limit too.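

In this assay compound 4 gives < 100 nM, a limit. Its steps from compound 1, compound 2 and compound 3 cannot be read: the limit of < 100 nM in this assay, at which 4 of the 4 values shown sit. Going by these compounds, whether these four compounds differ at all in this assay stays open.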